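Cyclic amine variation on a decyl-aryl oxadiazole series

This account rests on a few compounds, and the source may have more. Where it says the series, first, only, none or still open, it means among the compounds named here.

Measured so far:
compound 1, `CCCCCCCCCCc1ccc(-c2noc([C@@H]3CCNC3)n2)cc1`: 62%
compound 2, `CCCCCCCCCCc1ccc(-c2noc([C@H]3CCCN3)n2)cc1`: 12%
compound 3, `CCCCCCCCCCc1ccc(-c2noc(C3CCNCC3)n2)cc1`: 66%

In an assay on HeLa cells for inhibition of sphingosine-1-phosphate transporter SPNS2 (Mus musculus), read by LC-MS, tested at 2 uM (on this read-out higher numbers stand for more inhibition at the one concentration tested (going by the name of the read-out) and lower numbers for less inhibition), compound 3 gives the highest of the three numbers. Compound 1 and compound 3 sit within the scatter of each other, as the step of a number 4 percentage points higher from compound 1 to compound 3 (within the scatter) shows, so no order between these two can be read. Compound 2 stands apart: the steps of a number 50 percentage points lower from compound 1 to compound 2 (beyond the scatter) and a number 54 percentage points higher from compound 2 to compound 3 (beyond the scatter) are both large and beyond the scatter.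

The next compound, compound 4, is `CCCCCCCCCCc1ccc(-c2noc([C@@H]3CCC[C@@H](N)C3)n2)cc1`. It differs from compound 3 by 3-aminocyclohexyl in place of piperidin-4-yl on an aromatic carbon. Going by the values given here, none of the measured steps bears on this change directly. The step from compound 1 to compound 3 shows that ring size alone, with the amine kept inside the ring, changes little. The step from compound 1 to compound 2 shows that shifting the amine to another position costs much. Compound 4 keeps a six-membered ring but moves the amine outside it. For compound 4 the step expected from this change in this assay is estimated as a number 21 percentage points lower from compound 3 to compound 4 (beyond the scatter), though with wide uncertainty.

For compound 4 an estimated value of 45% is expected, in the range 20% to 70%.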

Compound 4, a percentage reported as inhibition, at one concentration (the size of the read-out at that concentration, not a potency): 13%
Estimate against measurement, compound 4: 32 percentage points above, outside the stated range (below it).
By their numbers in this assay, from the lowest: compounds 2 and 4 (each within the scatter of the next); then compounds 1 and 3 (each within the scatter of the next).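

In this assay, 3-aminocyclohexyl on the carbon of the shared core does not keep the level of the two better cyclic amines: the changes are a number 53 percentage points lower from compound 3 to compound 4 (beyond the scatter) and a number 49 percentage points lower from compound 1 to compound 4 (beyond the scatter), so a six-membered ring alone does not preserve the read-out at this position. The remaining step, a number 1 percentage points higher from compound 2 to compound 4 (within the scatter), places 3-aminocyclohexyl with pyrrolidin-2-yl in the low group, and compound 2 shows that an amine nitrogen inside the ring is not sufficient either. No measurement available here accounts for these differences.

Still open, on these data alone, is how the other stereoisomers of 3-aminocyclohexyl would read in this assay. Also open, as far as these compounds go, is whether a 4-aminocyclohexyl or piperidin-3-yl group would fall with the low or the high pair.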